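The source may hold more compounds than are shown below. What is called first, only, known or untested is meant among the compounds shown, and "the series" means these compounds.

Compound 2, `Cc1ccc(-c2cs/c(=N/NC(=O)CSc3nncn3C)n2-c2ccccc2)cc1`, in a functional assay on C6 cells (Rattus norvegicus) for cytotoxicity, read by MTT assay, with a stated time of 24 h (a higher number here means a weaker inhibitor, a lower number a stronger inhibitor), gives 56 ug/mL.
Compound 1, `Cn1nnnc1SCC(=O)N/N=c1/scc(-c2ccc(F)cc2)n1-c1ccccc1`, in this assay gives "not determined" (no result reported).
Compound 3, `Cn1cnnc1SCC(=O)N/N=c1/scc(-c2ccc(Br)cc2)n1-c1ccccc1`, in this assay gives "not determined" (no result reported).

Compound 2 thus stands alone: its number is the only one shown, and compounds 1 and 3 offer nothing to set beside it, so no step between measured compounds is known. Compound 4, `Cc1ccc(-c2cs/c(=N/NC(=O)CSc3nnnn3C)n2-c2ccccc2)cc1`, differs from compound 2 in one place: 1-methyl-1H-tetrazol-5-yl in place of 4-methyl-4H-1,2,4-triazol-3-yl on a sulfur. For the measured compounds named here, with a single number and no measured step to lean on, the step from compound 2 to compound 4 is expected to be small, within the usual scatter, with no clear direction: no change at the digits printed from compound 2 to compound 4 (within the scatter). The estimate for compound 4 in this assay is therefore 56 ug/mL, expected to fall between 25 ug/mL and 125 ug/mL.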

Compound 4, half-maximal inhibitory concentration: 36.3 ug/mL
For compound 4 the middle estimate is 1.5-fold (0.19 log units) above the measured one, within the range that was stated.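

In this assay, for the compounds shown here, the first pair that can be compared, with 1-methyl-1H-tetrazol-5-yl in place of 4-methyl-4H-1,2,4-triazol-3-yl on a sulfur, shows a 1.5-fold lower number from compound 2 to compound 4 (0.19 log units; within the scatter) and so no real separation between the two compounds. At this position, then, one of these rings can stand in for the other without a change that rises above the scatter. Nothing measured here bears on why the two compounds read alike. Still open, as far as these compounds go, is whether a group of another kind on this sulfur, such as a simple amine-bearing chain or a carboxylic acid, would move the number beyond the scatter.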